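The source may hold more compounds than are shown below. What is called first, only, known or untested is meant among the compounds shown, and "the series" means these compounds.

Compound 1 `CCCc1ccc(S(=O)(=O)NC(=O)OCCC(F)(F)C(F)(F)F)c(-c2ccc(Cn3c(C(C)(C)C)nc4ccccc43)cc2)c1` gives 6 nM in an assay on membranes from HEK293 cells for displacement of a labelled ligand from Type-2 angiotensin II receptor (Homo sapiens), read by radioligand binding; a lower number here means a stronger inhibitor, a higher number a weaker inhibitor.
Compound 3 `CCCc1ccc(S(=O)(=O)NC(=O)OCCCC(F)(F)F)c(-c2cc(F)c(Cn3c(C(C)(C)C)nc4ccccc43)c(F)c2)c1` gives 12 nM in this assay.
Compound 2 `CCCCOC(=O)NS(=O)(=O)c1ccc(CCC)cc1-c1ccc(Cn2c(-c3ccccc3)nc3ccccc32)cc1` gives 590 nM in this assay.

Of the three numbers, compound 2 stands highest: its value lies well beyond the scatter from compound 3 and further still from compound 1, so within this set it is the weakest binder. Among the measured compounds shown here, compounds 1 and 3 differ from compound 2 in more than one place at once, so no single step between measured compounds is given to lean on.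

Compound 4 `CCCCOC(=O)NS(=O)(=O)c1ccc(CCC)cc1-c1ccc(Cn2c(CC)nc3ccccc32)cc1` has not yet been measured. It differs from compound 2 in one place, (ethyl in place of phenyl on an aromatic carbon). For the measured compounds named here, with no measured step of this kind available, the expectation for this assay rests on the position of compound 2 alone, at the weak end of the set, and on the simple fact that a shorter group takes the place of the ring. A move towards the lower numbers of compounds 1 and 3 is thought likely, though of uncertain size, and the step from compound 2 is estimated at a 3.9-fold lower number from compound 2 to compound 4 (0.59 log units; beyond the scatter). Compound 4 is expected to give 150 nM in this assay, within a range of 40 nM to 600 nM.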

Compound 4, inhibition constant: 11 nM
Estimate against measurement, compound 4: 14-fold (1.13 log units) above; measured number outside the range, below it.
By their numbers in this assay, from the lowest: compounds 1, 4 and 3 (each within the scatter of the next); then compound 2.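

Among the compounds shown here, the change from phenyl to ethyl gives the first single-place comparison in this set. In this assay it produces a 54-fold lower number from compound 2 to compound 4 (1.73 log units; beyond the scatter) and is a large step, so the group on this carbon, between two ring nitrogen atoms and next to the ring atom that bears a large group, can by itself move the number far beyond the scatter. The earlier compounds shown here could not show this, as each differs from compound 2 in more than one place. Here, a six-membered aromatic ring of carbon only is lost and a group of 2 heavy atoms with no ring enters, with no hydrogen-bond donors, acceptors or net charge on either side of the change. No measurement offered here bears on what lies behind the size of this step.

The compounds shown leave open how a methyl group, a longer chain such as butyl, a cyclopropyl ring or an amine would fare at this carbon, and so whether ethyl stands out or simply belongs among many groups that give low numbers. From the compounds shown here alone, it also remains open whether phenyl has the same large effect when the rest of the molecule carries a different carbamate chain or a fluorinated central ring.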